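Swapping the aminophenyl for a dichlorophenyl on the carbonyl

The compounds below may be only part of what the source reports. "The series", "measured", "known", "first", "only" and "open" are said of these compounds alone.

Compound 1, `COc1ccc(-c2cc(/C=C/C(=O)c3ccc(N)cc3)[nH]n2)cc1`: 1080 nM
Compound 2, `COc1cc(-c2cc(/C=C/C(=O)c3ccc(N)cc3)[nH]n2)cc(OC)c1OC`: 1400 nM

Of the compounds shown here, two have been tested in a functional assay on OVCAR-4 cells (Homo sapiens) for inhibition, read by sulforhodamine B assay, with a stated time of 48 h; a lower number here means a stronger inhibitor of growth, a higher number a weaker inhibitor of growth. Compound 1 `COc1ccc(-c2cc(/C=C/C(=O)c3ccc(N)cc3)[nH]n2)cc1` gives 1080 nM, and compound 2 `COc1cc(-c2cc(/C=C/C(=O)c3ccc(N)cc3)[nH]n2)cc(OC)c1OC` gives 1400 nM. Compound 2 shows the higher of the two numbers, but the difference between them lies within the usual scatter, so the two compounds cannot be told apart here.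

Compound 3 `COc1cc(-c2cc(/C=C/C(=O)c3ccc(Cl)c(Cl)c3)[nH]n2)cc(OC)c1OC` has not yet been measured. It differs from compound 2 in a single place: 3,4-dichlorophenyl in place of 4-aminophenyl on a carbonyl carbon. The two measured compounds differ from each other elsewhere, so nothing measured shows what this particular exchange does in this assay. With no such guidance, the step is expected to be small, in no clear direction, and most likely within the scatter. Compound 3 is therefore estimated at 1100 nM, with a range from 300 nM to 4000 nM. That estimate corresponds to an expected step of a 1.3-fold lower number from compound 2 to compound 3 (0.10 log units; within the scatter).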

Compound 3, concentration for 50% growth inhibition: 10800 nM
Compound 3: the middle estimate sits 9.8-fold (0.99 log units) below what was measured; measured number above the stated range.
By their numbers in this assay, from the lowest: compounds 1 and 2 (each within the scatter of the next); then compound 3.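

In this assay, 3,4-dichlorophenyl in place of 4-aminophenyl on a carbonyl carbon brings a 7.7-fold higher number from compound 2 to compound 3 (0.89 log units; beyond the scatter), so growth inhibition here clearly depends on which group sits at this position, and this exchange weakens it. The group that leaves carries a hydrogen-bond donor and a hydrogen-bond acceptor, while the group that enters carries neither and brings chlorine instead. Nothing measured here explains why the number rises.

The exchange removes the amine and introduces the chlorines in one step, so the compounds shown leave open which of these two differences matters. A plain phenyl or a 4-chlorophenyl on the same carbonyl carbon would help to separate them, and a 4-hydroxyphenyl would show whether another group can stand in for the amine.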